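A few compounds are considered here, and "the series" means these few. Any claim that something is new, unique, unknown or untested is made for them only; others in the source may bear on it.

In a functional assay (Pituitary gland cell) with Rattus norvegicus as the target (a higher number here means that more compound is needed for the effect, a lower number that less compound is needed), compound 1 (`CC(C)(N)CC(=O)N[C@@H]1CCc2ccccc2N(Cc2ccc(-c3ccccc3C(=O)NCc3ccc(O)cc3)cc2)C1=O`) gives 0.3 uM, compound 2 (`CCN(CC)C(=O)c1ccccc1-c1ccc(CN2C(=O)[C@H](NC(=O)CC(C)(C)N)CCc3ccccc32)cc1`) gives 2 uM and compound 3 (`CC(C)(N)CC(=O)N[C@@H]1CCc2ccccc2N(Cc2ccc(-c3ccccc3C(=O)NCCO)cc2)C1=O`) gives 3 uM. The (2-hydroxyethyl)amino amide stands level with the diethylamino amide, a 1.5-fold higher number from compound 2 to compound 3 (0.18 log units; within the scatter). It stands clearly apart from the (4-hydroxybenzyl)amino amide, a 10-fold higher number from compound 1 to compound 3 (1.00 log units; beyond the scatter). The diethylamino amide is also apart from that amide, a 6.7-fold higher number from compound 1 to compound 2 (0.82 log units; beyond the scatter).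

Compound 4 (`CC(C)(N)CC(=O)N[C@@H]1CCc2ccccc2N(Cc2ccc(-c3ccccc3C(=O)NCCCCCO)cc2)C1=O`) changes compound 3 on a saturated chain carbon, two bonds along the chain from an amide-type nitrogen: 3-hydroxypropyl in place of hydroxy on a saturated chain carbon, two bonds along the chain from an amide-type nitrogen. The same difference reads (2-hydroxyethyl)amino to (5-hydroxypentyl)amino.

Among the measured compounds shown here, no measured step lengthens this chain alone, so the evidence is indirect. The closest guide is a 10-fold higher number from compound 1 to compound 3 (1.00 log units; beyond the scatter), where hydroxymethyl replaces 4-hydroxyphenyl on the same chain carbon. Read in reverse, that single step pairs the larger hydroxy-bearing group with the lower number. The step of a 1.5-fold higher number from compound 2 to compound 3 (0.18 log units; within the scatter) shows that a change at this amide need not move the number at all. A move towards lower numbers is therefore expected, smaller than the full step to compound 1, and the size is uncertain. The expected step is a 3.0-fold lower number from compound 3 to compound 4 (0.48 log units; beyond the scatter). For compound 4 the estimated value is 1 uM, with an expected range from 0.3 uM to 4 uM.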

Compound 4, concentration for half-maximal effect: 0.01 uM
For compound 4 the middle estimate is 100-fold (2.00 log units) above the measured one, and the stated range ends above it.
By their numbers in this assay, from the lowest: compound 4; then compound 1; then compounds 2 and 3 (each within the scatter of the next).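

In this assay, the amide substituent matters far more than the earlier pair suggested: compound 2 and compound 3 lay within the scatter of each other, yet 3-hydroxypropyl in place of hydroxy on the saturated chain carbon, two bonds along the chain from an amide-type nitrogen, gives a 300-fold lower number from compound 3 to compound 4 (2.48 log units; beyond the scatter). The (5-hydroxypentyl)amino amide also separates from the diethylamino amide, with a 200-fold lower number from compound 2 to compound 4 (2.30 log units; beyond the scatter), and from the (4-hydroxybenzyl)amino amide, with a 30-fold lower number from compound 1 to compound 4 (1.48 log units; beyond the scatter), so 4-hydroxybutyl in place of 4-hydroxyphenyl gives the lowest number of the four without a ring in that group. Nothing available here accounts for the size of these steps.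

The compounds shown do not separate the length of the chain from its terminal hydroxy group, and a plain pentyl amide would test that directly. On these data alone, with only two hydroxy-ended chains in hand, the dependence on length remains open, as do the effects of a longer hydroxyalkyl chain or of an amine or carboxylic acid at the end of the chain.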